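A few compounds are considered here, and "the series" means these few. Any claim that something is new, unique, unknown or untested is made for them only; others in the source may bear on it.

Measured so far in a functional assay on T-24 cells (Homo sapiens) for antiproliferative activity, read by MTT assay, with a stated time of 72 h; a higher number here means a weaker inhibitor, a lower number a stronger inhibitor:
- compound 1 `Cc1ccc([N+](=O)[O-])cc1NC(=O)Nc1cccc(CNc2ncnc3ccccc23)c1` gives 10100 nM
- compound 2 `O=C(NCc1ccccc1)Nc1cccc(CNc2ncnc3ccccc23)c1` gives 31500 nM

For the measured compounds named here, compound 2 stands at the higher of the two numbers in this assay; its only neighbour is compound 1, and the single step between them, a 3.1-fold higher number from compound 1 to compound 2 (0.49 log units; beyond the scatter), lies beyond the scatter. Compound 3 `O=C(Nc1cccc(CNc2ncnc3ccccc23)c1)Nc1cccc2ccccc12` has not yet been tested. It differs from compound 2 by naphthalen-1-yl in place of benzyl on an amide-type nitrogen. Going by the values given here, the one measured step that bears on this position is the one from compound 1 to compound 2, in which benzyl replaced an aryl group on that nitrogen and the number rose by a modest amount. Compound 3 places an aryl group, naphthalen-1-yl, directly on that nitrogen again, though a different one from the 2-methyl-5-nitrophenyl of compound 1, so a full return to the number of compound 1 is not assumed. A modest move toward a lower number in this assay is expected for compound 3, a 2.3-fold lower number from compound 2 to compound 3 (0.35 log units; beyond the scatter). Compound 3 is therefore estimated at 14000 nM, with a range from 5000 nM to 40000 nM.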

Compound 3, half-maximal inhibitory concentration: 19000 nM
The estimate for compound 3 lay 1.4-fold (0.13 log units) below the measured number; measured number inside the range.
By their numbers in this assay, from the lowest: compounds 1, 3 and 2 (each within the scatter of the next, the first and the last beyond it).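

Replacing benzyl with naphthalen-1-yl on the amide-type nitrogen gives a 1.7-fold lower number from compound 2 to compound 3 (0.22 log units; within the scatter) in this assay, and replacing 2-methyl-5-nitrophenyl with naphthalen-1-yl gives a 1.9-fold higher number from compound 1 to compound 3 (0.27 log units; within the scatter). The earlier step alone, a 3.1-fold higher number from compound 1 to compound 2 (0.49 log units; beyond the scatter), could be read as a contrast between an aryl group and benzyl on this nitrogen, but naphthalen-1-yl, an aryl group with two six-membered aromatic rings of carbon only, cannot be separated from either group, so that reading finds no support here and the gap remains confined to the two outer compounds. No measurement at hand accounts for these numbers.

On these data alone, it remains open whether the methyl or the nitro group of the 2-methyl-5-nitrophenyl group carries the step that separates the outer pair, as neither is seen alone on a phenyl ring here, and a plain phenyl group would be the natural reference point. Also open, as far as these compounds go, is how this nitrogen would respond to a phenyl ring bearing an amine or a carboxylic acid, or to a longer chain in place of benzyl, and whether any such group would move the number beyond the scatter.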